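The compounds below may be only part of what the source reports. "The series", "measured", "known", "first", "only" and "open" are said of these compounds alone.

Compound 1 `O=C(NCc1ccc(S(=O)(=O)c2ccccc2)cc1)c1nc2cnccc2[nH]1`: 73%
Compound 2 `O=C(NCc1ccc(S(=O)(=O)c2ccccc2C(F)(F)F)cc1)c1cc2cnccc2[nH]1`: 52%
Compound 3 `Cn1c(C(=O)NCc2ccc(S(=O)(=O)c3ccccc3)cc2)cc2cnccc21`: 78%

In an ADME assay on microsomes from liver (Homo sapiens) for metabolic stability, read by LC-MS, with a stated time of 30 min, tested at 1 uM (on this read-out higher numbers stand for a more stable compound and lower numbers for a less stable compound), compound 1 stands second highest of the three numbers. Its nearest neighbour is compound 3, whose value lies within the usual scatter of it, so the two cannot be told apart; the furthest is compound 2, whose value lies beyond the scatter, lower.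

Compound 4 `O=C(NCc1ccc(S(=O)(=O)c2ccccc2)cc1)c1cnc2nccn2c1` is not yet measured in this assay. It differs from compound 1 in one place: a group of 9 heavy atoms (6 carbon, 3 nitrogen; one five-membered aromatic ring with 2 hetero atoms, one six-membered aromatic ring with 2 hetero atoms) in place of a group of 9 heavy atoms (6 carbon, 3 nitrogen; one five-membered aromatic ring with 2 hetero atoms, one six-membered aromatic ring with 1 hetero atom), on a carbonyl carbon. Among the measured compounds shown here, no measured pair shows a step of this kind, so there is nothing to lean on beyond the values of compound 1 itself. The step of a number 5 percentage points lower from compound 1 to compound 4 (within the scatter) is therefore expected to stay within the scatter, with no clear direction. Compound 4 is estimated at 68%, in a range from 48% to 86%.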

Compound 4, percent of the compound remaining: 60%
Compound 4: the middle estimate sits 8 percentage points above what was measured; the range from low to high includes it.
By their numbers in this assay, from the lowest: compounds 2 and 4 (each within the scatter of the next); then compounds 1 and 3 (each within the scatter of the next).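

The same atoms joined differently on the carbonyl carbon are enough to matter in this assay, giving a number 13 percentage points lower from compound 1 to compound 4 (beyond the scatter). The group that enters has one more hetero atom in its six-membered ring and, unlike the group that leaves, no hydrogen-bond donor, so the atom count alone does not set this read-out. Nothing measured on these compounds explains the step.

Going by these compounds, compound 4 changes the donor and the ring nitrogens together, so which of the two goes with the step stays open. On these data alone, how a plain phenyl ring or a pyridine would behave on this carbonyl carbon is also open.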